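The compounds below may be only part of what the source reports. "The series", "measured", "known", "first", "only" and "open" are said of these compounds alone.

Measured compounds:
- compound 1 `COc1cc(-c2noc(-c3ccc(N)cc3)n2)cc(OC)c1OC`; in an ADME assay on cells (Splenocyte, Mus musculus, strain BALB/c) for cytotoxicity, read by CCK-8 assay, with a stated time of 48 h (on this read-out higher numbers stand for lower toxicity in this test and lower numbers for higher toxicity in this test), compound 1 gives > 50000 nM, a limit of the assay.
- compound 2 `COc1cc(-c2noc(-c3cccc(N)c3)n2)cc(OC)c1OC`; in this assay compound 2 gives 8200 nM.
- compound 3 `COc1cc(-c2noc(-c3cc(OC)c(OC)c(OC)c3)n2)cc(OC)c1OC`; in this assay compound 3 gives > 50000 nM, again a limit of the assay.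

Compound 1 thus stands at the limit of > 50000 nM in this assay, at which 2 of the 3 values shown sit, with no number of its own. Compound 4 `CCCCCCc1ccc(-c2nc(-c3cc(OC)c(OC)c(OC)c3)no2)cc1` differs from compound 1 by hexyl in place of amino on an aromatic carbon. Within the data shown here, the one measured step, an at least 6.0-fold lower number from compound 1 to compound 2 (0.78 log units; beyond the scatter), moves the amino group rather than replacing it, so it bears only loosely on this change; compounds 1 and 3 both sit at the limit. The expected step of an at least 1.6-fold lower number from compound 1 to compound 4 (0.22 log units; that floor lies within the scatter) is therefore small, most likely again a limit. Compound 4 is estimated at 30000 nM, range 8000 nM to 50000 nM.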

Compound 4, half-maximal cytotoxic concentration: 25000 nM
Beside the measured number, compound 4's estimate is 1.2-fold (0.08 log units) above it; the measured number falls inside the stated range.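

Replacing the amino group with hexyl on this aromatic carbon gives, in this assay, an at least 2.0-fold lower number from compound 1 to compound 4 (0.30 log units; that floor lies within the scatter). Compound 4 therefore provides a number at this position, with a hexyl chain in place, and the floor of the step does not establish a real change. The value of compound 1 is a limit: the limit of > 50000 nM in this assay, at which 2 of the 4 values shown sit.

Going by these compounds, the true size of the step stays open, and so does whether the chain length matters. A shorter butyl chain, a longer octyl chain or a carboxylic acid on the same carbon would test whether a number appears with other groups here.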